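The source may hold more compounds than are shown below. What is called first, only, known or untested is meant among the compounds shown, and "the series" means these compounds.

Measured so far:
compound 1, `C[C@@H]1CN(c2sc(C3COC3)nc2-c2nc3ccccc3[nH]2)CCN1C(=O)Cn1cnc2cccnc21`: in a functional assay on CHO-K1 cells for antagonist activity at C-X-C chemokine receptor type 3 (Homo sapiens), read by FLIPR, with a stated time of 10 min (a lower number here means a stronger inhibitor, a higher number a weaker inhibitor), compound 1 gives 53 nM
compound 2, `C[C@@H]1CN(c2sc(CN(C)C)nc2-c2nc3ccccc3[nH]2)CCN1C(=O)Cn1cnc2cccnc21`: in this assay compound 2 gives 50 nM

Compound 2 gives the lowest of the two numbers, but the gap to compound 1 is within the scatter. Compound 3, `C[C@@H]1CN(c2sc(C(F)(F)F)nc2-c2nc3ccccc3[nH]2)CCN1C(=O)Cn1cnc2cccnc21`, carries trifluoromethyl in place of (dimethylamino)methyl on an aromatic carbon. Going by the values given here, the only measured step touching this position, a 1.1-fold lower number from compound 1 to compound 2 (0.03 log units; within the scatter), barely moved the number, so this spot tolerates a change of group. The new group differs from both earlier ones, so a modest shift either way is possible; in this assay compound 3 is expected near compound 2, with a step of a 1.2-fold higher number from compound 2 to compound 3 (0.08 log units; within the scatter), giving an estimate of 60 nM in the range 25 nM to 150 nM.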

Compound 3, half-maximal inhibitory concentration: 1.6 nM
Estimate against measurement, compound 3: 38-fold (1.57 log units) above; the measured number lies below the stated range.
By their numbers in this assay, from the lowest: compound 3; then compounds 2 and 1 (each within the scatter of the next).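

This position is less forgiving than the first pair suggested. In this assay, trifluoromethyl in place of (dimethylamino)methyl gives (a 31-fold lower number from compound 2 to compound 3 (1.49 log units; beyond the scatter)), and in place of oxetan-3-yl it gives (a 33-fold lower number from compound 1 to compound 3 (1.52 log units; beyond the scatter)), so the group on this aromatic carbon can move the number strongly, even though the two earlier groups lie within the scatter of each other. Nothing available explains this difference.

As far as these compounds go, it remains open whether trifluoromethyl is special here, or whether methyl, chlorine or a nitrile would give a similarly low number. From the compounds shown here alone, it is also open whether the effect would hold with other changes to the shared core.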